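The compounds below may be only part of what the source reports. "The series", "measured", "known", "first", "only" and "open" are said of these compounds alone.

Compound 1 `Oc1ccc(-c2cc(-c3ccccc3O)cc(-c3ccccc3O)n2)cc1` is one of two compounds with numbers in a functional assay on DU-145 cells (Homo sapiens) for cytotoxicity, read by CCK-8 assay, with a stated time of 4 days (a lower number here means a stronger inhibitor, a higher number a weaker inhibitor), where compound 1 gives 360 nM. The other, compound 2 `Oc1ccc(-c2cc(-c3cccc(O)c3)nc(-c3cccc(O)c3)c2)cc1`, gives 1760 nM in this assay, so compound 1 holds the lower of the two numbers, and the gap to compound 2 lies beyond the usual scatter. Compound 3 `Oc1ccc(-c2cc(-c3ccc(O)cc3)nc(-c3ccccc3O)c2)cc1` has not yet been measured. It is built from the same atoms as compound 1, joined differently: 4-hydroxyphenyl in place of 2-hydroxyphenyl on an aromatic carbon. Going by the values given here, no step between two measured compounds matches this change, so the expectation rests on the two numbers alone. The hydroxyl positions on the outer rings appear to matter, since compound 2 sits far above compound 1; a modest rise is therefore expected, with the step of a 1.9-fold higher number from compound 1 to compound 3 (0.29 log units; within the scatter) estimated as small to moderate. Compound 3 is expected to give about 700 nM in this assay, with a likely range from 250 nM to 2000 nM.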

Compound 3, half-maximal inhibitory concentration: > 50000 nM
Compound 3 ended at the assay's limit (the forecaster's own chance of this, stated with the estimate: 5%); middle value at least 71-fold (1.85 log units) away from the limit.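

In this assay, placing 4-hydroxyphenyl instead of 2-hydroxyphenyl on the aromatic carbon opposite the ring nitrogen gives an at least 130-fold higher number from compound 1 to compound 3 (2.14 log units; beyond the scatter). The two groups have the same heavy atoms and the same counts of hydrogen-bond donors and acceptors, so this position responds strongly to how the atoms are joined, not only to which atoms are present. The value of compound 3 is a limit of the assay and not a number, so the true size of this step stays unknown: the limit of > 50000 nM in this assay, at which 1 of the 3 values shown sits.

The compounds shown do not reveal why this swap matters so much. They also leave open whether the hydroxyl of the 2-hydroxyphenyl group is itself needed, a question that a plain phenyl, 2-methoxyphenyl or 2-aminophenyl group at this position would address.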